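This account rests on a few compounds, and the source may have more. Where it says the series, first, only, none or still open, it means among the compounds named here.

Measured compounds in a functional assay on HEK293 cells for agonist activity at Bombesin receptor subtype-3 (Homo sapiens), read by luminescence and calcium flux, with a stated time of 10 min; on this read-out lower numbers stand for an effect already at smaller amounts and higher numbers for an effect only at larger amounts of compound:
compound 1 `CCC(C)(C)Cc1c[nH]c(CCc2ccc(-c3cnccn3)cc2)n1`, 100 nM
compound 2 `CCC(C)(C)Cc1c[nH]c(CCc2ccc(-c3csnn3)cc2)n1`, 104 nM
compound 3 `CCC(C)(C)Cc1c[nH]c(CCc2ccc(-n3cncn3)cc2)n1`, 89 nM

Compound 3 gives the lowest of the three numbers, yet all three sit within the scatter of one another: a 1.1-fold lower number from compound 1 to compound 3 (0.05 log units; within the scatter), a 1.2-fold lower number from compound 2 to compound 3 (0.07 log units; within the scatter), and a 1.0-fold higher number from compound 1 to compound 2 (0.02 log units; within the scatter). Compound 4 `CCC(C)(C)Cc1c[nH]c(CCc2ccc(-c3ccns3)cc2)n1` differs from compound 3 by 1,2-thiazol-5-yl in place of 1H-1,2,4-triazol-1-yl on an aromatic carbon. Each measured step at this position is a swap of one small aromatic ring for another, and none of them moved this assay beyond the scatter, so the same is expected for the present swap, with no step in either direction beyond the scatter. Compound 4 is therefore expected at 95 nM, range 40 nM to 250 nM, which means an expected step of a 1.1-fold higher number from compound 3 to compound 4 (0.03 log units; within the scatter).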

Compound 4, half-maximal effective concentration: 102 nM
For compound 4 the middle estimate is 1.1-fold (0.03 log units) below the measured one; the range from low to high includes it.
By their numbers in this assay, from the lowest: compounds 3, 1, 4 and 2 (each within the scatter of the next).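

In this assay the 1,2-thiazol-5-yl group falls in with the other rings at this position (a 1.1-fold higher number from compound 3 to compound 4 (0.06 log units; within the scatter)) (a 1.0-fold lower number from compound 2 to compound 4 (0.01 log units; within the scatter)) (a 1.0-fold higher number from compound 1 to compound 4 (0.01 log units; within the scatter)). Among the compounds shown here, this is the first sulfur-bearing ring with 2 hetero atoms here, and going from 3 hydrogen-bond acceptors to 2 leaves the number within the scatter. Nothing available explains this flatness.

Open is whether any group at this place moves the number beyond the scatter, since only small aromatic rings are shown; an amine, a carboxylic acid or a longer chain would test that.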